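The compounds below may be only part of what the source reports. "The series", "measured", "known", "first", "only" and "open" are said of these compounds alone.

Measured so far in a functional assay on MCF7 cells (Homo sapiens) for antiproliferative activity; on this read-out lower numbers stand for stronger inhibition and higher numbers for weaker inhibition:
- compound 1 `CC(C)=CCc1cc(C(=O)Nc2cc3ccc(OCC4CCCN(C)C4)c(C)c3oc2=O)ccc1O` gives 2640 nM
- compound 2 `COC(=O)CNCCCOc1ccc2cc(NC(=O)c3ccc(O)c(CC=C(C)C)c3)c(=O)oc2c1C` gives 2820 nM

These two numbers cannot be told apart. Within the data shown here, the only measured step, a 1.1-fold higher number from compound 1 to compound 2 (0.03 log units; within the scatter), stays within the scatter, so compound 2 stands level with compound 1.

Next is compound 3 `CC(C)=CCc1cc(C(=O)Nc2cc3ccc(OCCCNCC(N)=O)c(C)c3oc2=O)ccc1O`, which carries amino in place of methoxy on a carbonyl carbon, so that methoxycarbonyl becomes carbamoyl. Among the measured compounds shown here, no measured step tests this change directly. For the measured compounds named here, the one step available put 2-(((methoxycarbonyl)methyl)amino)ethyl in place of 1-methylpiperidin-3-yl on a saturated chain carbon bound to an oxygen on an aromatic ring, and it gives only indirect guidance. Going by the values given here, with compound 2 at 2820 nM as the anchor and that step as the only guide, no shift beyond the scatter is expected in this assay. The expected step is a 1.1-fold higher number from compound 2 to compound 3 (0.03 log units; within the scatter), and with so little data the range is kept wide. Compound 3 is estimated at 3000 nM (expected range 1200 nM to 7500 nM).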

Compound 3, half-maximal inhibitory concentration: 1460 nM
Beside the measured number, compound 3's estimate is 2.1-fold (0.31 log units) above it; the measured number falls inside the stated range.
By their numbers in this assay, from the lowest: compounds 3, 1 and 2 (each within the scatter of the next).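

In this assay, amino in place of methoxy on a carbonyl carbon whose other neighbour is a saturated chain carbon gives a 1.9-fold lower number from compound 2 to compound 3 (0.29 log units; within the scatter), so this first direct test of the position shows that methoxycarbonyl and carbamoyl cannot be told apart on this read-out, even though amino brings a hydrogen-bond donor that methoxy lacks. The comparison with the 1-methylpiperidin-3-yl side chain reads the same way, with a 1.8-fold lower number from compound 1 to compound 3 (0.26 log units; within the scatter), so the carbamoyl side chain also adds no step beyond the scatter, and neither the ester nor the primary amide separates from the piperidine in this small set. No supporting measurement bears on this result.

The compounds shown leave open whether a carboxylic acid or a dimethylamino group on the same carbonyl carbon would move the number beyond the scatter. They also leave open whether a longer chain in place of carbamoylmethyl on the side-chain amine would do so, and with only these three compounds, any tolerance at this position remains a reading of methoxy and amino alone.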